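Extending an Ester Chain: Half-Life of Compound 3

The source may report more compounds than this note shows. Statements on the series, on what has been measured and on what is new or still open speak of the compounds shown alone.

Compound 1, `CCOC(=O)/C=C/c1ccc(NC(=O)C2(NC(=O)c3ccc4c(C5CCCC5)c(-c5ncc(Cl)cn5)n(C)c4c3)CCC2)cc1OCC`, in an ADME assay on a cell-free system (plasma, Homo sapiens) for pharmacokinetics (a higher number here means that the compound lasts longer, a lower number that the compound disappears faster), gives > 5 h, which is a limit of the assay rather than a number. Compound 2, `CCCOC(=O)/C=C/c1ccc(NC(=O)C2(NC(=O)c3ccc4c(C5CCCC5)c(-c5ncc(Cl)cn5)n(C)c4c3)CCC2)cc1OCC`, in this assay gives > 5 h, also a limit.

Within the data shown here, for compound 2, then, only a limit is known in this assay, and the one other value shown is a limit as well (the limit of > 5 h in this assay, at which 2 of the 2 values shown sit). Among the measured compounds shown here, the single measured step, a step that the two limits leave unreadable from compound 1 to compound 2, therefore cannot be read for size or direction. Compound 3, `CCOc1cc(NC(=O)C2(NC(=O)c3ccc4c(C5CCCC5)c(-c5ncc(Cl)cn5)n(C)c4c3)CCC2)ccc1/C=C/C(=O)OCC(C)C`, differs from compound 2 by methyl in place of hydrogen on a saturated chain carbon bound to two saturated chain carbons. For the measured compounds named here, no measured step bears readably on this change, so no shift beyond the usual scatter in this assay is expected, and the expected step is a step that the limit leaves unreadable from compound 2 to compound 3. Compound 3 is therefore estimated to give 8 h in this assay, between 4 h and 16 h, most likely reported again as a limit.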

Compound 3, half-life: 6.18 h
Beside the measured number, compound 3's estimate is 1.3-fold (0.11 log units) above it; low and high end bracket the measured number.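

In this assay compound 1 and compound 2 are known only as limits, so neither step to compound 3 can be read for size or direction: the limit of > 5 h in this assay, at which 2 of the 3 values shown sit. The compounds shown leave open whether changing the ester chain from ethyl through propyl to isobutyl alters the half-life at all.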